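Triazole aromatase series: loss of a nitrile

This account rests on a few compounds, and the source may have more. Where it says the series, first, only, none or still open, it means among the compounds named here.

Measured so far:
compound 1 `N#Cc1ccc(C(c2ccc(C#N)cc2)n2cc(COc3ccccc3)nn2)cc1` with 11000 nM
compound 2 `N#Cc1ccc(OCc2cn(C(c3ccc(C#N)cc3)c3ccc(C#N)cc3)nn2)cc1` with 4640 nM
compound 3 `N#Cc1ccc(Cn2nccn2)cc1` with 12200 nM

In an assay on isolated protein for inhibition of Aromatase (Homo sapiens), read by fluorescence and colorimetric assay, with a stated time of 30 min (on this read-out lower numbers stand for stronger inhibition and higher numbers for weaker inhibition), compound 2 and compound 1 differ by hydrogen in place of cyano on an aromatic carbon. That change gives a 2.4-fold higher number from compound 2 to compound 1 (0.37 log units; beyond the scatter). Compound 3 carries a much smaller core than compound 2; the difference between the two cores is not broken down here. In this assay compound 3 sits close to compound 1, within the scatter.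

Compound 4 `c1ccc(Cn2nccn2)cc1` is unmeasured. It differs from compound 3 by hydrogen in place of cyano on an aromatic carbon. This is the same kind of change as from compound 2 to compound 1, though the place differs in what the cyano stands para to: a large group in compound 2, a group of 6 heavy atoms in compound 3.

For compound 4 the expected step is a 2.1-fold higher number from compound 3 to compound 4 (0.33 log units; beyond the scatter), in the same direction as the measured one, resting on compound 1 with 11000 nM against compound 2. Compound 4 is therefore estimated at 26000 nM, with 10000 nM to 70000 nM as the expected range.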

Compound 4, half-maximal inhibitory concentration: 16300 nM
Estimate against measurement, compound 4: 1.6-fold (0.20 log units) above; low and high end bracket the measured number.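

In this assay, hydrogen in place of cyano on the smaller core gives a 1.3-fold higher number from compound 3 to compound 4 (0.13 log units; within the scatter). Set beside the earlier step, the gap between the two cores cannot be told from the scatter: the same change on two cores in this assay, a 2.4-fold higher number (0.37 log units; beyond the scatter) from compound 2 to compound 1 and a 1.3-fold higher number (0.13 log units; within the scatter) from compound 3 to compound 4, 1.8-fold (0.25 log units) apart, within the scatter of two such steps. This shows that the change can be carried between these two cores without a measurable difference in its size, but it does not show that the two steps are equal, and the step on the smaller core alone does not stand clear of the scatter.

Two pairs give no rule for other cores in the series. Still open, from the compounds shown here alone, is what a carboxylic acid, an amine or a methoxy group would give in place of the cyano on either core.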